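The compounds below may be only part of what the source reports. "The series", "measured", "known", "first", "only" and "open" are said of these compounds alone.

For the measured compounds named here, in a physicochemical assay for lipophilicity (a lower number here means a more polar compound, a higher number a more lipophilic compound), compound 1 `C/C=C/C=C/C(=O)OCC` gives 1.84 and compound 2 `C/C=C/C=C/C(=O)OCCC` gives 2.31, so compound 2 holds the higher of the two numbers so far. The next compound, compound 3 `C/C=C/C=C/C(=O)OC(C)C`, changes only the chain on the ester: isopropyl in place of propyl on an oxygen next to a carbonyl group. Going by the values given here, only one measured step bears on this change, and only loosely. That step is a number 0.47 log units higher from compound 1 to compound 2 (beyond the scatter), and it puts a methyl in place of hydrogen on a saturated chain carbon. Compound 3 instead has the same atoms as compound 2, joined differently, so a much smaller change is expected, slightly downward and possibly within the scatter. The expected step is a number 0.16 log units lower from compound 2 to compound 3 (within the scatter). For compound 3 the estimated value is 2.15, with an expected range from 1.9 to 2.4.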

Compound 3, partition coefficient: 2.26
Beside the measured number, compound 3's estimate is 0.11 log units below it; the measured number falls inside the stated range.
By their numbers in this assay, from the lowest: compound 1; then compounds 3 and 2 (each within the scatter of the next).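

In this assay the arrangement of the chain on an oxygen next to a carbonyl group makes no readable difference: isopropyl in place of propyl gives a number 0.05 log units lower from compound 2 to compound 3 (within the scatter), so these two chains, built from the same atoms, cannot be told apart here. In the two cases shown, methyl in place of hydrogen moves the number beyond the scatter whether it forms the branched chain, with a number 0.42 log units higher from compound 1 to compound 3 (beyond the scatter), or the straight one, with a number 0.47 log units higher from compound 1 to compound 2 (beyond the scatter). Nothing at hand explains either result. The compounds shown leave open whether a longer chain on this oxygen would keep raising the number or whether a ring there would behave like isopropyl. They also leave open how far an amine or a carboxylic acid on the chain would move it, and in which direction.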